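From Chloro to Methoxy: Compound 3 to Compound 4

The compounds below may be only part of what the source reports. "The series", "measured", "known", "first", "only" and "open" are said of these compounds alone.

Three compounds share one core and differ only in the group on the six-membered aromatic ring of carbon only. Compound 1 `C/C(=C\c1cc(-c2ccc(C#N)cc2)cs1)C(N)=O` carries cyano, and in a functional assay on HO8910 cells (Homo sapiens) for cytotoxicity, read by CCK-8 assay, with a stated time of 24 h (on this read-out lower numbers stand for stronger inhibition and higher numbers for weaker inhibition), compound 1 gives 130 nM. Compound 2 `C/C(=C\c1cc(-c2ccc(S(C)(=O)=O)cc2)cs1)C(N)=O` carries methylsulfonyl instead. In this assay compound 2 gives only a limit of the assay, > 50000 nM. Compound 3 `C/C(=C\c1cc(-c2ccc(Cl)cc2)cs1)C(N)=O` carries chloro. In this assay compound 3 also gives only a limit, > 50000 nM, so its true number is not known. Two of the three values shown sit at this same limit (the limit of > 50000 nM in this assay, at which 2 of the 3 values shown sit). The steps of an at least 380-fold higher number from compound 1 to compound 2 (2.58 log units; beyond the scatter) and an at least 380-fold higher number from compound 1 to compound 3 (2.58 log units; beyond the scatter) show that leaving cyano costs a great deal, while the step that the two limits leave unreadable from compound 2 to compound 3 cannot be read from the two limits.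

The change to compound 4 `COc1ccc(-c2csc(/C=C(\C)C(N)=O)c2)cc1` is methoxy in place of chloro on an aromatic carbon. Among the compounds with values here, no measured step covers this exact change; the two readable steps only show that cyano stands far ahead of both groups tried in its place. Compound 4 is therefore expected to remain weak in this assay. The expected step of a number no higher from compound 3 to compound 4 (the limit leaves the size open) is within the scatter. The estimate for compound 4 in this assay is 50000 nM, within 5000 nM to 200000 nM.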

Compound 4, half-maximal inhibitory concentration: > 50000 nM
Compound 4 was reported as a limit (the forecaster's own chance of this, stated with the estimate: 65%); the middle value lies on the limit itself.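

Replacing cyano with methoxy gives an at least 380-fold higher number from compound 1 to compound 4 (2.58 log units; beyond the scatter), so methoxy joins methylsulfonyl and chloro as a third group at this position, on an aromatic carbon para to a large group, that falls far behind cyano. Compound 4 brings in a hydrogen-bond acceptor that chloro lacks, yet in this assay compound 4 still gives only a limit of the assay. The steps among compound 2, compound 3 and compound 4 cannot be read, and most of the set now rests on one limit: the limit of > 50000 nM in this assay, at which 3 of the 4 values shown sit.

Among the compounds shown, only cyano gives a true number, so it remains open how far the activity of compound 1 is particular to cyano. From the compounds shown here alone, whether an amine, a carboxylic acid or a longer chain in this place would also give a true number remains unknown, as do the true values of compound 2, compound 3 and compound 4.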